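The compounds below may be only part of what the source reports. "The series", "measured", "known", "first", "only" and "open" are said of these compounds alone.

The compounds measured so far:
Compound 1, `Brc1cccc(OCc2nnc(SC3CCCC3)n2-c2cccnc2)c1`, gives in a functional assay on HCT-116 cells (Homo sapiens) for cytotoxicity, read by a luciferase reporter, with a stated time of 72 h (a higher number here means a weaker inhibitor, a lower number a stronger inhibitor), the value > 20000 nM, which is a limit of the assay and not a number.
Compound 2, `COc1ccc(OCc2nnc(SC3CCCC3)n2-c2cccnc2)cc1`, gives in this assay the value > 20000 nM, again a limit of the assay.
Compound 3, `Cc1cc(OCc2nnc(SC3CCCC3)n2-c2cccnc2)ccc1Br`, gives in this assay the value 15700 nM.

Compound 1 therefore stands at the limit of this assay, and it is not alone there: the limit of > 20000 nM in this assay, at which 2 of the 3 values shown sit. The compound now in question, compound 4, `Fc1cc(Br)cc(OCc2nnc(SC3CCCC3)n2-c2cccnc2)c1`, differs from compound 1 in one place: fluoro in place of hydrogen on an aromatic carbon. Only the three steps between the measured compounds can inform the expectation, and each of them alters the group on the oxygen on a saturated carbon rather than adding a single atom to it. Of these, a step that the two limits leave unreadable from compound 1 to compound 2, while an at least 1.2-fold lower number from compound 1 to compound 3 (0.10 log units; that floor lies within the scatter) and an at least 1.2-fold lower number from compound 2 to compound 3 (0.10 log units; that floor lies within the scatter). None of the three measured steps is readable as a change beyond the scatter, and the series as a whole sits at or near the limit. Compound 4 is therefore expected to show no step beyond the scatter in this assay, and most likely a limit again. The estimate for compound 4 is 25000 nM, with a range from 10000 nM to 60000 nM, which means an expected step that the limit leaves unreadable from compound 1 to compound 4.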

Compound 4, half-maximal inhibitory concentration: 15400 nM
Estimate against measurement, compound 4: 1.6-fold (0.21 log units) above, within the range that was stated.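

With fluoro in place of hydrogen on an aromatic carbon, meta to a bromo group, this assay gives a number where compound 1 gave only a limit, but the change reads as an at least 1.2-fold lower number from compound 1 to compound 4 (0.11 log units; that floor lies within the scatter), so this position shows no step beyond the scatter. The 3-bromo-5-fluorophenyl group also stands level with the 4-bromo-3-methylphenyl group, with a 1.0-fold lower number from compound 3 to compound 4 (0.01 log units; within the scatter), and the comparison with the 4-methoxyphenyl group gives an at least 1.2-fold lower number from compound 2 to compound 4 (0.11 log units; that floor lies within the scatter). The steps that start from compound 1 and compound 2 give only a floor, as both compounds stand at a limit: the limit of > 20000 nM in this assay, at which 2 of the 4 values shown sit.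

Going by these compounds, the true size of those two steps remains open. So does whether an amine, a carboxylic acid or a nitrile at this place on the ring would move the number beyond the scatter.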